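Inverting One Ring Carbon of an Endoperoxide Acid

The source may hold more compounds than are shown below. What is called first, only, known or untested is meant among the compounds shown, and "the series" means these compounds.

Compound 1 `CC(=O)CC/C=C(\C)CCC1=C(C)CCCC1(C)C` — in a functional assay on SK-OV-3 cells (Homo sapiens) for inhibition (a higher number here means a weaker inhibitor of growth, a lower number a stronger inhibitor of growth), compound 1 gives > 15000 nM
Compound 2 `C=C1CCCC(C)(C)C1CC[C@]1(C)CC[C@@H]([C@@H](C)C(=O)O)OO1` — in this assay compound 2 gives > 10000 nM
Compound 3 `C=C1CCC[C@H]2[C@](C)(CC[C@]3(C)CC[C@@H]([C@@H](C)C(=O)O)OO3)[C@@H](C)CC[C@]12C` — in this assay compound 3 gives 970 nM

Of the compounds shown here, three have been tested so far. For compound 1, the result is a limit of this assay, not a number (the limit of > 15000 nM in this assay, at which 1 of the 3 values shown sits). For compound 2, the result is likewise a limit (the limit of > 10000 nM in this assay, at which 1 of the 3 values shown sits). Compound 3 is therefore the only one of the three with a measured number in this assay, and it stands alone: the other two values are limits and cannot be ranked against it.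

The step under study leads from compound 3 to compound 4 `C=C1CCC[C@H]2[C@](C)(CC[C@]3(C)CC[C@H]([C@@H](C)C(=O)O)OO3)[C@@H](C)CC[C@]12C`. The two compounds have the same atoms and bonds and differ only in configuration as drawn (the two compounds have the same atoms and bonds and differ only in configuration as drawn: 1 of 7 stereo elements differ; a stereocentre at a saturated ring carbon is drawn S in compound 3 and R in compound 4). Within the data shown here, no measured pair in this set shows what such a change of configuration does in this assay, so there is no precedent to lean on.

With only a single stereocentre inverted and everything else kept, the expectation is for a change not far beyond the scatter, leaning toward a somewhat weaker inhibitor; the step from compound 3 to compound 4 is estimated at a 1.6-fold higher number from compound 3 to compound 4 (0.22 log units; within the scatter). Compound 4 is thus expected to give about 1600 nM in this assay, within a range from 500 nM to 6000 nM.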

Compound 4, concentration for 50% growth inhibition: 1570 nM
Compound 4: the middle estimate sits 1.0-fold (0.01 log units) above what was measured, within the range that was stated.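

Among these compounds, this is the first pair in the set that isolates a single change of configuration, here at a saturated ring carbon, whereas the earlier compounds offered no such comparison. In this assay the inversion amounts to a 1.6-fold higher number from compound 3 to compound 4 (0.21 log units; within the scatter) and so does not separate the two configurations at this carbon: with this read-out, the way this one centre is drawn makes no difference that can be told from ordinary repeat-to-repeat variation. The comparison is unusually clean, since nothing else in the structures can contribute to the result: the fact that compounds 3 and 4 differ only in the configuration as drawn.

The compounds shown leave open whether inverting any of the other stereocentres would have just as little effect, or whether this insensitivity is particular to the one carbon examined here. They also leave open whether the same inversion would remain as inconsequential in a compound carrying a methyl ester or an amide in place of the carboxylic acid, so this single pair cannot yet be read as a general rule for the series.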